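A few compounds are considered here, and "the series" means these few. Any claim that something is new, unique, unknown or untested is made for them only; others in the source may bear on it.

Measured so far in an assay on isolated protein for displacement of a labelled ligand from melanin-concentrating hormone receptor 1 (Homo sapiens); a lower number here means a stronger inhibitor, a higher number a weaker inhibitor:
Compound 1 `NC1CCN(c2ccc3cc(NC(=O)CCc4ccc(C(F)(F)F)cc4)ccc3n2)C1` gives 12 nM.
Compound 2 `O=C(CCc1ccc(C(F)(F)F)cc1)Nc1ccc2nc(N3CC4CC3CN4)ccc2c1` gives 210 nM.
Compound 3 `CCCc1cc(N(C)C)c2cc(NC(=O)CCc3ccc(C(F)(F)F)cc3)ccc2n1` gives 12 nM.

Compound 2 carries the highest number of the three; in this assay the nearest, compound 1, sits an 18-fold higher number from compound 1 to compound 2 (1.24 log units; beyond the scatter), and compound 3 sits equally far off. Compound 4 `O=C(CCc1ccc(C(F)(F)F)cc1)Nc1ccc2nc(N3CCC3)ccc2c1` differs from compound 2 only at this position: a group of 4 heavy atoms (3 carbon, 1 nitrogen; one four-membered non-aromatic ring with 1 hetero atom) in place of a group of 7 heavy atoms (5 carbon, 2 nitrogen; 2 five-membered non-aromatic rings with 1 hetero atom each), on an aromatic carbon. Going by the values given here, the one step that touches the same site is an 18-fold higher number from compound 1 to compound 2 (1.24 log units; beyond the scatter), where the smaller ring bearing a donor was replaced by the larger bicyclic group and the number rose sharply. Compound 4 removes that bicyclic group again, but enters a group without a donor, so the data give no direct guide. Compound 4 is expected at 150 nM (range 40 nM to 600 nM), the step of a 1.4-fold lower number from compound 2 to compound 4 (0.15 log units; within the scatter) being estimated as modest.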

Compound 4, half-maximal inhibitory concentration: 4 nM
The estimate for compound 4 lay 38-fold (1.57 log units) above the measured number; the whole stated range lies above it.
By their numbers in this assay, from the lowest: compound 4; then compounds 1 and 3 (each within the scatter of the next); then compound 2.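

In this assay, this position accepts a group with no hydrogen-bond donor: azetidin-1-yl brings a 53-fold lower number from compound 2 to compound 4 (1.72 log units; beyond the scatter). It also improves on 3-aminopyrrolidin-1-yl, with a 3.0-fold lower number from compound 1 to compound 4 (0.48 log units; beyond the scatter), so a donor on this group is not needed for a low number. Across compound 4, compound 1 and compound 2, the number rises as the group gains heavy atoms, a pattern resting on these three compounds alone.

No measurement at hand accounts for these steps. Still open, on these data alone, is whether ring size or the amine drives them, a question that pyrrolidin-1-yl and 3-aminoazetidin-1-yl could separate.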